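The compounds below may be only part of what the source reports. "The series", "measured", "known", "first", "only" and "open" are said of these compounds alone.

In an ADME assay on BCBL1 cells (Homo sapiens) for cytotoxicity, with a stated time of 7 days (on this read-out higher numbers stand for lower toxicity in this test and lower numbers for higher toxicity in this test), three compounds sharing one core have been measured. Compound 1 `Nc1nc(OCC(F)(F)F)c2ncn(/C=C3/CC3(CO)CO)c2n1` returns only a limit, > 20000 nM. Compound 2 `C=CCOc1nc(N)nc2c1ncn2/C=C1/CC1(CO)CO` also returns only a limit, > 20000 nM. Within the data shown here, compound 3 `Nc1nc(NCc2ccccc2)c2ncn(/C=C3/CC3(CO)CO)c2n1` gives the only actual number, 19900 nM. Compound 4 `CSc1nc(N)nc2c1ncn2/C=C1/CC1(CO)CO` carries methylsulfanyl in place of benzylamino on an aromatic carbon. The steps that change this same carbon are a number no higher from compound 1 to compound 3 (the limit leaves the size open) and a number no higher from compound 2 to compound 3 (the limit leaves the size open), and neither has a readable size. The best guide is therefore (the limit of > 20000 nM in this assay, at which 2 of the 3 values shown sit). No clear step beyond the usual scatter is expected in either direction, so the expected change is a 1.0-fold higher number from compound 3 to compound 4 (0.00 log units; within the scatter). For compound 4, the estimated value is 20000 nM, with an expected range from 8000 nM to 50000 nM.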

Compound 4, half-maximal cytotoxic concentration: > 20000 nM
Compound 4 was reported as a limit; the forecaster's own chance of this, stated with the estimate: 60%; the middle value sits exactly at the limit.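

Putting methylsulfanyl on this aromatic carbon in place of benzylamino gives a number no lower from compound 3 to compound 4 (the limit leaves the size open). Among these compounds, a sulfur-linked group with no ring therefore joins the two oxygen-linked groups in reaching the limit, and compound 3 remains the only compound with an actual number: the limit of > 20000 nM in this assay, at which 3 of the 4 values shown sit. The steps from compound 1 and from compound 2 to compound 4 cannot be read, since both ends of each are limits.

As far as these compounds go, how far the limited compounds lie past that limit stays open. So does whether an amine such as dimethylamino or a longer chain such as butylsulfanyl on this carbon would give a clearly lower number.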